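The source may hold more compounds than are shown below. What is called first, only, known or untested is meant among the compounds shown, and "the series" means these compounds.

Measured compounds:
- compound 1 `O=C(CCC1CCCCC1)Nc1ncc(Cc2ccccc2)s1`: in an ADME assay on P388D1 cells (Mus musculus) for cytotoxicity, read by fluorescence and resazurin assay, with a stated time of 72 h (on this read-out higher numbers stand for weaker inhibition and lower numbers for stronger inhibition), compound 1 gives > 40000 nM
- compound 2 `CCc1cnc(NC(=O)CCC2CCCCC2)s1`: in this assay compound 2 gives "not determined" (no result reported)
- compound 3 `O=C(CCC1CCCCC1)Nc1ncc(Cc2ccnc3ccccc23)s1`: in this assay compound 3 gives "not determined" (no result reported)

The value for compound 1 in this assay is a limit of the assay and not a number. For compound 2 and compound 3 no result is reported in this assay, so compound 3 stands without a number of its own; the only entry with any content in the series is the limit at which compound 1 sits, as in the limit of > 40000 nM in this assay, at which 1 of the 3 values shown sits. Going by the values given here, no pair of measured compounds differs in a single place, so no step has been measured.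

Compound 4 `O=C(Nc1ncc(Cc2ccnc3ccccc23)s1)C1CCCCC1` is the next compound to be measured. It differs from compound 3 by cyclohexyl in place of 2-cyclohexylethyl on a carbonyl carbon. With the shared core held and one value in the series sitting at a limit, the step in this assay from compound 3 to compound 4 is expected to be none beyond the scatter. Compound 4 is therefore expected to give about 40000 nM in this assay, within a range of 20000 nM to 80000 nM, and most likely to be reported as a limit rather than a number.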

Compound 4, half-maximal inhibitory concentration in the P388D1 assay: 13900 nM
Estimate against measurement, compound 4: 2.9-fold (0.46 log units) above; the measured number lies below the stated range.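

No new step can be read in the P388D1 assay: compound 3 has no number there to set against compound 4. In a physicochemical assay for solubility, at pH 5 (on this read-out lower numbers stand for lower solubility and higher numbers for higher solubility), compound 3 gives 5 ug/mL and compound 4 gives 130 ug/mL. The compounds shown leave open whether cyclohexyl in place of 2-cyclohexylethyl changes the cytotoxicity read-out.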